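A few compounds are considered here, and "the series" means these few. Any claim that something is new, unique, unknown or untested is made for them only; others in the source may bear on it.

Measured compounds:

compound 1 `O=C(CCC1C(=O)N(c2ccc(Cl)cc2)C(=O)N1Cc1ccccc1)Nc1ccc(C(=O)NO)cc1` — 7.6 nM
compound 2 `O=C(CCC1C(=O)N(c2ccc(Cl)cc2)C(=O)N1Cc1ccccc1)NCc1ccc(C(=O)NO)cc1` — 12.7 nM
compound 3 `CN1C(=O)N(c2ccc(Cl)cc2)C(=O)C1CCC(=O)Nc1ccc(C(=O)NO)cc1` — 7 nM

Of the compounds shown here, three have been measured in an assay on isolated protein for inhibition of protein deacetylase HDAC6 (Homo sapiens), read by fluorescence, with stated times of 5 min and 60 min; on this read-out lower numbers stand for stronger inhibition and higher numbers for weaker inhibition. Compound 1 gives 7.6 nM, compound 2 gives 12.7 nM, and compound 3 gives 7 nM. All three numbers lie within the usual scatter of one another.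

Compound 2 differs from compound 1 by 4-(hydroxycarbamoyl)benzyl in place of 4-(hydroxycarbamoyl)phenyl on an amide-type nitrogen, and this step reads a 1.7-fold higher number from compound 1 to compound 2 (0.22 log units; within the scatter). Compound 3 differs from compound 1 by hydrogen in place of phenyl on a saturated chain carbon bound to an amide-type nitrogen in a ring, a step of a 1.1-fold lower number from compound 1 to compound 3 (0.04 log units; within the scatter).

The unmeasured compound 4 `CN1C(=O)N(c2ccc(Cl)cc2)C(=O)C1CCC(=O)NCc1ccc(C(=O)NO)cc1` differs from compound 2 by hydrogen in place of phenyl on a saturated chain carbon bound to an amide-type nitrogen in a ring. This is the same change as that from compound 1 to compound 3, made on the same place, and it occurs twice among these compounds. The two cores differ as described for compound 1 and compound 2, so compound 4 carries the core of compound 2 with the phenyl removed as in compound 3.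

The expected step for compound 4 is a 1.1-fold lower number from compound 2 to compound 4 (0.02 log units; within the scatter), essentially no movement, because a 1.1-fold lower number from compound 1 to compound 3 (0.04 log units; within the scatter) shows that the same change from compound 1 left the number where it was. Among the compounds with values here, with only one earlier example of this change and no independent reading of the core swap, the spread of the expectation is kept broad. In this assay compound 4 is expected to give about 12 nM, with the range from 6 nM to 25 nM.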

Compound 4, half-maximal inhibitory concentration: 11.8 nM
Compound 4: middle estimate off by 1.0-fold (0.01 log units), on the high side; measured number inside the range.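

In this assay, hydrogen in place of phenyl on a saturated chain carbon bound to an amide-type nitrogen in a ring, which reads benzyl to methyl when cut one bond further out, gives a 1.1-fold lower number from compound 2 to compound 4 (0.03 log units; within the scatter) on the core carrying 4-(hydroxycarbamoyl)benzyl. Set beside the earlier step on the core carrying 4-(hydroxycarbamoyl)phenyl, the change carries over from one core to the other with no reading of a difference: the same change on two cores in this assay, a 1.1-fold lower number (0.04 log units; within the scatter) from compound 1 to compound 3 and a 1.1-fold lower number (0.03 log units; within the scatter) from compound 2 to compound 4, 1.0-fold (0.00 log units) apart, within the scatter of two such steps. Within the data shown here, this shows only that the change left the number in place on both of these closely related cores; two pairs make no rule for the whole series, and steps this small do not show what the benzyl contributes or whether the same would hold on a core further removed from these.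

The compounds shown leave open what an amine, a carboxylic acid or a longer chain would read in place of the benzyl or the methyl in this assay. They also leave open whether the same flat reading would survive with a carboxylic acid in place of the hydroxycarbamoyl group, or with a hydrogen in place of the chlorine on the ring.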